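A few compounds are considered here, and "the series" means these few. Any claim that something is new, unique, unknown or untested is made for them only; others in the source may bear on it.

Measured so far:
compound 1 `COCCO[C@H]1CC[C@H]2CCN(C)[C@H]2C1`: in an assay on HEK293 cells for antagonist activity at Nicotinic acetylcholine receptor alpha-4/beta-2 (Mus musculus), read by FLIPR, using a membrane potential dye (on this read-out higher numbers stand for weaker inhibition and lower numbers for stronger inhibition), compound 1 gives > 300000 nM, which is a limit of the assay.
compound 2 `COCCO[C@H]1CC=C2CCN(C)[C@H]2C1`: in this assay compound 2 gives > 300000 nM, again a limit.
compound 3 `CN1CC[C@@H]2CC[C@H](O)C[C@@H]21`: in this assay compound 3 gives > 300000 nM, also a limit.

From compound 1 to compound 3 the change is hydrogen in place of 2-methoxyethyl on an oxygen on a saturated carbon; the step it made is a step that the two limits leave unreadable from compound 1 to compound 3, and because of the limit of > 300000 nM in this assay, at which 3 of the 3 values shown sit, its size cannot be read. The core of compound 2 differs from the core of compound 1; the difference between the two cores is not broken down here. Compound 4 `CN1CCC2=CC[C@H](O)C[C@@H]21` is still to be measured in this assay and differs from compound 2 by hydrogen in place of 2-methoxyethyl on an oxygen on a saturated carbon, the same change, made at a place described in the same words. With all three measured values sitting at the limit, there is nothing to suggest that this change brings the value into the readable range, so the expected step from compound 2 to compound 4 is a number no higher from compound 2 to compound 4 (the limit leaves the size open), resting on a step that the two limits leave unreadable from compound 1 to compound 3. Compound 4 is therefore estimated at 300000 nM, most probably reported once more only as a limit.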

Compound 4, half-maximal inhibitory concentration: > 100000 nM
Compound 4 gave a limit, no number (the forecaster's own chance of this, stated with the estimate: 85%); the middle value is on the limit's open side.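

In this assay compound 4 gives > 100000 nM, a limit of the assay. Compound 2 gives > 300000 nM, also a limit. No step can be read between compound 2 and compound 4. The compounds shown leave open how 2-methoxyethoxy and hydroxy compare on this read-out, and whether any compound in the series gives a readable value.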